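Trifluoromethyl replacing anilino in an acylguanidine series

A few compounds are considered here, and "the series" means these few. Any claim that something is new, unique, unknown or untested is made for them only; others in the source may bear on it.

Compound 2 `Cc1cc(Nc2ccccc2)c(S(C)(=O)=O)cc1C(=O)N=C(N)N` gives 21 nM in a functional assay for inhibition of sodium/hydrogen exchanger (Oryctolagus cuniculus); a lower number here means a stronger inhibitor, a higher number a weaker inhibitor. Among the two numbers on hand it stands lowest, but its nearest neighbour, compound 1 `Cc1cc(-n2cccn2)c(S(C)(=O)=O)cc1C(=O)N=C(N)N`, with 25 nM in this assay, lies within the scatter of it, so no order between the two can be claimed. The step of a 1.2-fold lower number from compound 1 to compound 2 (0.08 log units; within the scatter) shows that exchanging one ring for another at this place moved the number little. The new compound 3 `Cc1cc(C(F)(F)F)c(S(C)(=O)=O)cc1C(=O)N=C(N)N` carries trifluoromethyl in place of anilino on an aromatic carbon. Going by the values given here, only the step from compound 1 to compound 2 bears on this change, and it was within the scatter; no measured compound carries a group without a ring at this place, so the bearing is indirect. Compound 3 is therefore expected to give 35 nM in this assay, within a range of 10 nM to 120 nM, an estimated step of a 1.7-fold higher number from compound 2 to compound 3 (0.22 log units; within the scatter) that may well stay within the scatter.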

Compound 3, half-maximal inhibitory concentration: 37 nM
Beside the measured number, compound 3's estimate is 1.1-fold (0.02 log units) below it; the range from low to high includes it.
By their numbers in this assay, from the lowest: compounds 2, 1 and 3 (each within the scatter of the next).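

Going by these compounds alone, compound 3 is the first compound here with no ring at this place, ortho to a methylsulfonyl group, and the step of a 1.8-fold higher number from compound 2 to compound 3 (0.25 log units; within the scatter) and the step of a 1.5-fold higher number from compound 1 to compound 3 (0.17 log units; within the scatter) both stay within the scatter of this assay. Anilino, with its 7 heavy atoms, aromatic ring and hydrogen-bond donor, can therefore give way to trifluoromethyl, with 4 heavy atoms, no ring and no donor, without a difference this assay can resolve, so neither a ring nor that donor is shown to be needed here. Nothing measured here explains this outcome.

As far as these compounds go, whether a primary amine, a carboxylic acid or a longer alkyl chain at this place would also stay within the scatter remains open. So does whether any group here can separate itself from these three compounds, which this set cannot rank.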